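The compounds below may be only part of what the source reports. "The series", "measured", "known", "first", "only" and "open" are said of these compounds alone.

Measured compounds in an ADME assay for permeability, using PAMPA, with a stated time of 30 min, at pH 7.4; a higher number here means that the compound crosses the layer faster, a lower number that the compound crosses the layer more slowly:
compound 1, `COc1cccc(CNCCCNc2ccnc3cc(-c4ccc(C(C)(C)C)cc4)ccc23)c1O`: 237 10^-6 cm/s
compound 2, `CC(C)(C)c1ccc(-c2ccc3c(NCCCNCc4ccco4)ccnc3c2)cc1`: 237 10^-6 cm/s
compound 3, `COc1ccc(F)cc1CNCCCNc1ccnc2cc(-c3ccc(C(C)(C)C)cc3)ccc12`: 237 10^-6 cm/s

Compound 2 stands level with compounds 1 and 3 in this assay; the three readings are the same at the digits given, and no order among them can be drawn. Compound 4, `c1coc(CNCCCNc2ccnc3cc(C4CCCCC4)ccc23)c1`, has not been measured there. The change from compound 2 to compound 4 is the following: cyclohexyl in place of 4-(tert-butyl)phenyl on an aromatic carbon.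

Three steps are known among the measured compounds, and every one of them exchanges the group on a saturated chain carbon bound to an amine nitrogen: no change at the digits printed from compound 1 to compound 2 (within the scatter), no change at the digits printed from compound 1 to compound 3 (within the scatter), no change at the digits printed from compound 2 to compound 3 (within the scatter). Within the data shown here, none of them touches the group on the aromatic carbon of the fused system, so no step bears directly on the change to compound 4. What the known steps do show is that the reading has stayed put through three different groups on the chain carbon. The expectation for compound 4 therefore rests on the reading of compound 2, 237 10^-6 cm/s, and no shift beyond the scatter is expected, no change at the digits printed from compound 2 to compound 4 (within the scatter). Compound 4 is estimated at 237 10^-6 cm/s, within 110 10^-6 cm/s to 300 10^-6 cm/s.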

Compound 4, apparent permeability: 23 10^-6 cm/s
For compound 4 the middle estimate is 10-fold (1.01 log units) above the measured one; the whole stated range lies above it.
By their numbers in this assay, from the lowest: compound 4; then compounds 1, 2 and 3 (each within the scatter of the next).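

In this assay the group on an aromatic carbon of a six-membered aromatic ring of carbon only, part of a fused or bridged system of two rings, matters to the reading in a way the chain position did not show: cyclohexyl in place of 4-(tert-butyl)phenyl gives a 10-fold lower number from compound 2 to compound 4 (1.01 log units; beyond the scatter), while all three exchanges on the saturated chain carbon bound to an amine nitrogen stayed within the scatter. The two groups differ in heavy atoms and in the ring, aromatic against non-aromatic, but not in hydrogen-bond donors, hydrogen-bond acceptors or net charge, so the step goes with a difference in ring type and size alone. No measurement at hand accounts for this step.

The compounds shown do not separate the loss of the aromatic ring from the loss of the tert-butyl group, and an unsubstituted phenyl or a 4-(tert-butyl)cyclohexyl at this position would tell the two apart. Among these compounds, it also remains open whether the chain position stays as flat with cyclohexyl in place, since furan-2-yl is the only chain group paired with it.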